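Benzamide in Place of the Acrylate on a Ring Carbon

The compounds below may be only part of what the source reports. "The series", "measured", "known", "first", "only" and "open" are said of these compounds alone.

Measured compounds:
Compound 1, `CC(C)S(=O)(=O)OC1CCC(CN2CCN(c3cc(=O)c4cc(C(F)(F)F)cc([N+](=O)[O-])c4s3)CC2)CC1`, gives in an ADME assay on Vero cells (Chlorocebus sabaeus) for cytotoxicity, read by MTT assay, with a stated time of 48 h (a lower number here means a stronger inhibitor, a higher number a weaker inhibitor), the value > 64 ug/mL, which is a limit of the assay rather than a number.
Compound 2, `O=c1cc(N2CCN(CC3CCC(OS(=O)(=O)c4cccnc4)CC3)CC2)sc2c([N+](=O)[O-])cc(C(F)(F)F)cc12`, gives in this assay the value > 64 ug/mL, again a limit.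
Compound 3, `C=CC(=O)OC1CCC(CN2CCN(c3cc(=O)c4cc(C(F)(F)F)cc([N+](=O)[O-])c4s3)CC2)CC1`, gives in this assay the value > 64 ug/mL, also a limit.

Compound 3 thus stands where all three measured compounds stand, at the limit of > 64 ug/mL in this assay, at which 3 of the 3 values shown sit. The steps a step that the two limits leave unreadable from compound 1 to compound 3 and a step that the two limits leave unreadable from compound 2 to compound 3 cannot be sized, as only limits are known at both ends, and the same holds for a step that the two limits leave unreadable from compound 1 to compound 2.

Compound 4, `O=C(NC1CCC(CN2CCN(c3cc(=O)c4cc(C(F)(F)F)cc([N+](=O)[O-])c4s3)CC2)CC1)c1ccccc1`, differs from compound 3 in one place: benzamido in place of (vinylcarbonyl)oxy on a saturated ring carbon. Among the measured compounds shown here, no measured step involves the benzamido group, so none of them speaks directly to this change; what they do show is that varying the group on this saturated ring carbon has so far never brought a compound below the limit. The expected step that the limit leaves unreadable from compound 3 to compound 4 is therefore none beyond the scatter, with compound 4 most likely remaining at the limit. Compound 4 is estimated at 80 ug/mL, in the range 40 ug/mL to 200 ug/mL.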

Compound 4, half-maximal inhibitory concentration: 44.3 ug/mL
Estimate against measurement, compound 4: 1.8-fold (0.26 log units) above; low and high end bracket the measured number.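

In this assay compound 4 gives 44.3 ug/mL, a measured number for a compound with benzamido on this saturated ring carbon. Compound 1, compound 2 and compound 3 each remain at a limit of the assay: the limit of > 64 ug/mL in this assay, at which 3 of the 4 values shown sit. Placing benzamido on this carbon gives an at least 1.4-fold lower number from compound 3 to compound 4 (0.15 log units; that floor lies within the scatter), an at least 1.4-fold lower number from compound 2 to compound 4 (0.15 log units; that floor lies within the scatter) and an at least 1.4-fold lower number from compound 1 to compound 4 (0.15 log units; that floor lies within the scatter); each of these is only a floor, so the true size of the change remains unknown and it may or may not go beyond the scatter.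

The compounds shown do not separate the amide link from the added aromatic ring, and a benzoate ester or an acetamido group at this ring carbon would tell these two parts apart. Also open, on these data alone, is how a free amine or a carboxylic acid on this carbon would read in this assay.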